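Swapping the amide aryl group of compound 3

This account rests on a few compounds, and the source may have more. Where it says the series, first, only, none or still open, it means among the compounds named here.

In a functional assay on MCF7 cells (Homo sapiens) for antiproliferative activity, read by MTT assay, with a stated time of 24 h (on this read-out lower numbers stand for stronger inhibition and higher numbers for weaker inhibition), compound 1 (`COC(=O)c1scc(-c2ccc(NC(=O)c3ccc4ccccc4c3)cc2)c1OC`) gives 90 nM, compound 2 (`COC(=O)c1scc(-c2ccc(NC(=O)c3cccc(I)c3)cc2)c1OC`) gives 12300 nM and compound 3 (`COC(=O)c1scc(-c2ccc(NC(=O)c3cc(I)ccc3F)cc2)c1OC`) gives 22500 nM. Compound 3 therefore stands level with compound 2 and far from compound 1. The added fluoro group accounts for only a 1.8-fold higher number from compound 2 to compound 3 (0.26 log units; within the scatter), whereas replacing naphthalen-2-yl gives a 140-fold higher number from compound 1 to compound 2 (2.14 log units; beyond the scatter) and a 250-fold higher number from compound 1 to compound 3 (2.40 log units; beyond the scatter).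

The next change leads to compound 4 (`COC(=O)c1scc(-c2ccc(NC(=O)c3ccc(C#N)nc3)cc2)c1OC`): 6-cyanopyridin-3-yl in place of 2-fluoro-5-iodophenyl on a carbonyl carbon. In words, this is 6-cyanopyridin-3-yl in place of 2-fluoro-5-iodophenyl on a carbonyl carbon. For the measured compounds named here, no measured step introduces a ring nitrogen or a nitrile, so the data offer only indirect guidance. The two large steps show that the group on the carbonyl carbon can move the number widely, but both start from naphthalen-2-yl, which compound 4 does not carry. Compounds 2 and 3 each hold one six-membered aromatic ring there and remain close, and compound 4 also holds one such ring. Only a small shift is therefore expected, with a slight lean towards a lower number.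

The expected step in this assay is a 1.9-fold lower number from compound 3 to compound 4 (0.27 log units; within the scatter). For compound 4 the estimate is 12000 nM, with an expected range of 2000 nM to 50000 nM.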

Compound 4, half-maximal inhibitory concentration: 9540 nM
Estimate against measurement, compound 4: 1.3-fold (0.10 log units) above; low and high end bracket the measured number.
By their numbers in this assay, from the lowest: compound 1; then compounds 4, 2 and 3 (each within the scatter of the next, the first and the last beyond it).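

In this assay, the amide aryl group no longer needs a halogen to give a number in the range of the iodinated compounds: replacing 2-fluoro-5-iodophenyl with 6-cyanopyridin-3-yl gives a 2.4-fold lower number from compound 3 to compound 4 (0.37 log units; beyond the scatter), a modest step, while replacing 3-iodophenyl gives a 1.3-fold lower number from compound 2 to compound 4 (0.11 log units; within the scatter). Adding a ring nitrogen and a nitrile does not bring the series close to the naphthalen-2-yl amide, as a 110-fold higher number from compound 1 to compound 4 (2.03 log units; beyond the scatter) shows, so all three single-ring groups shown stay far from compound 1. No supporting measurement bears on these steps, and their origin remains unassigned.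

The ring nitrogen and the nitrile enter together in compound 4, so the shown data cannot assign the step from compound 3 to either one alone. From the compounds shown here alone, it also remains open whether the low number of compound 1 is specific to naphthalen-2-yl, or how an unsubstituted phenyl, or a phenyl carrying an amine or a carboxylic acid, would stand on the same carbonyl carbon.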